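This account rests on a few compounds, and the source may have more. Where it says the series, first, only, none or still open, it means among the compounds named here.

Four compounds built on a shared core are compared in an ADME assay on MT4 cells (Homo sapiens) for cytotoxicity, read by MTT assay, with a stated time of 5 days; on this read-out lower numbers stand for higher toxicity in this test and higher numbers for lower toxicity in this test. Compound 1 `COc1cc2nc(SCC(=O)Nc3cccc(S(N)(=O)=O)c3)nc(Nc3c(Cl)cc(/C=C/C#N)cc3Cl)c2cc1OC` reaches only a limit of this assay, > 194000 nM. Compound 2 `COc1cc2nc(SCC(=O)Nc3ccc(S(N)(=O)=O)cc3)nc(Nc3c(Cl)cc(/C=C/C#N)cc3Cl)c2cc1OC` gives 116000 nM in this assay. Compound 3 `COc1cc2nc([S+]([O-])CC(=O)Nc3cccc(S(N)(=O)=O)c3)nc(Nc3c(Cl)cc(/C=C/C#N)cc3Cl)c2cc1OC` gives 67800 nM in this assay, the lowest of the numbers measured, though its gap to compound 2 stays within the usual scatter of repeated measurements. Compound 4 `COc1cc2nc([S+]([O-])CC(=O)Nc3ccc(S(N)(=O)=O)cc3)nc(Nc3c(Cl)cc(/C=C/C#N)cc3Cl)c2cc1OC` has not been measured yet.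

The difference between compound 1 and compound 2 is 4-sulfamoylphenyl in place of 3-sulfamoylphenyl on an amide-type nitrogen. That change made an at least 1.6-fold lower number from compound 1 to compound 2 (0.22 log units; that floor lies within the scatter); since compound 1 sits at the limit of > 194000 nM in this assay, at which 1 of the 3 values shown sits, the exact size of this step is not fixed, only its floor. The difference between the cores of compound 3 and compound 1 is not broken down here. Compound 4 differs from compound 3 by the same change, at the same place: 4-sulfamoylphenyl in place of 3-sulfamoylphenyl on an amide-type nitrogen.

For the measured compounds named here, only this one earlier instance of the change is available to judge it. Given an at least 1.6-fold lower number from compound 1 to compound 2 (0.22 log units; that floor lies within the scatter), which did not clearly leave the scatter, the expected step is a 1.5-fold lower number from compound 3 to compound 4 (0.18 log units; within the scatter), small and pointing to a somewhat lower number. Compound 4 is accordingly estimated to give about 45000 nM in this assay, with the likely range running from 20000 nM to 120000 nM.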

Compound 4, half-maximal cytotoxic concentration: > 189000 nM
Compound 4 gave a limit, no number; the forecaster's own chance of this, stated with the estimate: 10%; middle value at least 4.2-fold (0.62 log units) from the limit.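

On the core of compound 3, putting 4-sulfamoylphenyl in place of 3-sulfamoylphenyl on the amide-type nitrogen gave an at least 2.7-fold higher number from compound 3 to compound 4 (0.44 log units; beyond the scatter) in this assay, so the change cannot be carried from one core to the other as a single fixed step, and the size seen on the core of compound 1 is a poor guide to its size on the core of compound 3: the same change on two cores in this assay, an at least 1.6-fold lower number (0.22 log units; that floor lies within the scatter) from compound 1 to compound 2 and an at least 2.7-fold higher number (0.44 log units; beyond the scatter) from compound 3 to compound 4, at least 4.6-fold (0.66 log units) apart, beyond the scatter of two such steps

The result for compound 4 is a limit and not a number, so it shows a floor for the new step and neither its exact size nor why the two cores behave differently: the limit of > 189000 nM in this assay, at which 1 of the 4 values shown sits.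

The result for compound 1 is a limit as well, so the earlier step is likewise known only by its floor, and the true gap between the two steps remains unfixed: the limit of > 194000 nM in this assay, at which 1 of the 4 values shown sits.

For the compounds shown here, with only two cores and two placements of the sulfamoyl group in view, it remains open how the change would behave on any further core. On these data alone, it is also open how this read-out would respond if a carboxylic acid or an amine stood in place of the sulfamoyl group on the phenyl ring.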